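A few compounds are considered here, and "the series" means these few. Any claim that something is new, unique, unknown or untested is made for them only; others in the source may bear on it.

Of the compounds shown here, three of one series have been measured in an assay on isolated protein for antagonist activity at Bile acid receptor (Homo sapiens), read by HTRF, with a stated time of 30 min; a higher number here means a weaker inhibitor, a lower number a stronger inhibitor. Compound 1, `CCCCc1cc(C(C)=O)c(OCc2ccccc2)cc1OCCCCCC(C)(C)c1nnn[nH]1`, gives 7800 nM. Compound 2, `CCc1cc(C(C)=O)c(OCc2ccccc2)cc1OCCCCCC(C)(C)c1nnn[nH]1`, gives 1100 nM. Compound 3, `CCCCC(=O)c1cc(CC)c(OCCCCCC(C)(C)c2nnn[nH]2)cc1O`, gives 5400 nM. The difference between the core of compound 2 and the core of compound 3 is not broken down here. Compound 4, `CCCCCCC(=O)c1cc(CC)c(OCCCCCC(C)(C)c2nnn[nH]2)cc1O`, has not yet been measured in this assay.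

Compound 1 differs from compound 2 by ethyl in place of hydrogen on a saturated chain carbon, two bonds along the chain from an aromatic carbon, and this change made a 7.1-fold higher number from compound 2 to compound 1 (0.85 log units; beyond the scatter). Compound 4 differs from compound 3 by ethyl in place of hydrogen on a saturated chain carbon, four bonds along the chain from a carbonyl carbon. The change is the same kind of change, but not the same: in compound 1 the ethyl enters two bonds along the chain from an aromatic carbon, whereas in compound 4 it enters four bonds along the chain from a carbonyl carbon.

Because the earlier step from compound 2 to compound 1 was a 7.1-fold higher number from compound 2 to compound 1 (0.85 log units; beyond the scatter), a weaker result is expected for compound 4 as well, though the different place of the change leaves the size open. The step from compound 3 to compound 4 is estimated at a 2.8-fold higher number from compound 3 to compound 4 (0.44 log units; beyond the scatter). Compound 4 is therefore expected to give 15000 nM in this assay, estimated to lie between 5000 nM and 45000 nM.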

Compound 4, half-maximal inhibitory concentration: 8400 nM
Compound 4: middle estimate off by 1.8-fold (0.25 log units), on the high side, within the range that was stated.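

In this assay the ethyl in place of hydrogen gave a 1.6-fold higher number from compound 3 to compound 4 (0.19 log units; within the scatter), so on the core of compound 3 the step cannot be told apart from the scatter, and the two cores did not respond alike: the same change on two cores in this assay, a 7.1-fold higher number (0.85 log units; beyond the scatter) from compound 2 to compound 1 and a 1.6-fold higher number (0.19 log units; within the scatter) from compound 3 to compound 4, 4.6-fold (0.66 log units) apart, beyond the scatter of two such steps This shows that the size of the step seen on the core of compound 2 did not carry over to the core of compound 3, although the place of the change also differs, two bonds along the chain from an aromatic carbon in one pair and four bonds along the chain from a carbonyl carbon in the other. It does not show whether the core or the place accounts for the gap, as the two pairs differ in both, and a single pair on each core gives no rule for other cores in the series.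

The compounds shown leave open whether the same change, made at one and the same place on both cores, would give steps that agree. They also leave open how a longer chain at that place, or a chain ending in a carboxylic acid or an amine, would read on either core.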